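This account rests on a few compounds, and the source may have more. Where it says the series, first, only, none or still open, it means among the compounds named here.

In an in vivo functional assay on the whole organism for inhibition, with Rattus norvegicus as the target (a higher number here means that more compound is needed for the effect, a lower number that less compound is needed), compound 3 `CCCCc1nc(C)c(CC(=O)N2CCOCC2)c(=O)n1Cc1ccc(-c2ccccc2-c2nnn[nH]2)cc1` gives 0.018 mg/kg. In this assay, compound 1 `CCCCc1nc(C)c(CC(=O)N2CCC[C@H]2C(N)=O)c(=O)n1Cc1ccc(-c2ccccc2-c2nnn[nH]2)cc1` gives 0.023 mg/kg. Among the measured compounds shown here, the two numbers lie within the scatter of each other, so compound 3 sits level with the only other measured member of the series. For the measured compounds named here, for compound 2 `CCCCc1nc(C)c(CC(=O)N2CCN(C)CC2)c(=O)n1Cc1ccc(-c2ccccc2-c2nnn[nH]2)cc1` the entry reads "not determined" (no result reported), so it has no reported result and adds no step. Compound 4 `CCCCc1nc(C)c(CCC(=O)N2CCCCC2)c(=O)n1Cc1ccc(-c2ccccc2-c2nnn[nH]2)cc1` has not yet been measured. It carries ((piperidin-1-yl)carbonyl)methyl in place of (morpholin-4-yl)carbonyl on a saturated chain carbon bound to an aromatic carbon. Going by the values given here, one measured step bears on this change: a 1.3-fold lower number from compound 1 to compound 3 (0.11 log units; within the scatter), with morpholin-4-yl in place of 2-carbamoylpyrrolidin-1-yl on a carbonyl carbon. Among the compounds with values here, that step stays within the scatter, yet no measured step covers the change from ((morpholin-4-yl)carbonyl)methyl to 2-((piperidin-1-yl)carbonyl)ethyl, so the guidance is thin. The expected change is a 1.7-fold higher number from compound 3 to compound 4 (0.22 log units; within the scatter), an estimate that leans slightly towards a higher number without passing beyond the scatter. For compound 4 the estimated value is 0.03 mg/kg, with an expected range from 0.01 mg/kg to 0.09 mg/kg.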

Compound 4, dose for half-maximal effect: 0.164 mg/kg
Estimate against measurement, compound 4: 5.5-fold (0.74 log units) below, outside the stated range (above it).
By their numbers in this assay, from the lowest: compounds 3 and 1 (each within the scatter of the next); then compound 4.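

In this assay this position proves sensitive to change: going to the 2-((piperidin-1-yl)carbonyl)ethyl group gives a 9.1-fold higher number from compound 3 to compound 4 (0.96 log units; beyond the scatter), and the comparison with the other measured amide gives a 7.1-fold higher number from compound 1 to compound 4 (0.85 log units; beyond the scatter). The earlier step, which exchanged only the group on the carbonyl carbon, stayed within the scatter, so the tolerance seen there does not extend to this change. Nothing measured here offers an explanation for the rise.

Compound 4 differs from compound 3 in both the chain and the ring on the amide, so the compounds shown cannot say which of the two carries the step. A 2-((morpholin-4-yl)carbonyl)ethyl group and a ((piperidin-1-yl)carbonyl)methyl group on the shared core would each change only one of them, and neither is among the compounds shown.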